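The source may hold more compounds than are shown below. What is called first, only, known or untested is meant among the compounds shown, and "the series" means these compounds.

Of the compounds shown here, three built on the same core have been measured in a functional assay on NCI-H23 cells (Homo sapiens) for cytotoxicity, read by sulforhodamine B assay, with a stated time of 72 h; a higher number here means a weaker inhibitor of growth, a lower number a stronger inhibitor of growth. Compound 1, `O=C(Nc1cc(C(F)(F)F)cc(C(F)(F)F)c1)C1CCc2ccccc2N1C(=O)c1cccc(Cl)c1`, gives 420 nM. Compound 2, `O=C(Nc1cc(C(F)(F)F)cc(C(F)(F)F)c1)C1CCc2ccccc2N1C(=O)c1ccccc1Cl`, gives 2080 nM. Compound 3, `O=C(Nc1cc(C(F)(F)F)cc(C(F)(F)F)c1)C1CCc2ccccc2N1`, gives 8410 nM, the highest of the three numbers and so the weakest inhibitor of growth among them; compound 2 lies nearest to it and compound 1 furthest. Two measured steps show what happens when the group on the ring nitrogen is removed: a 20-fold higher number from compound 1 to compound 3 (1.30 log units; beyond the scatter), and a 4.0-fold higher number from compound 2 to compound 3 (0.61 log units; beyond the scatter). Between the two acylated compounds, a 5.0-fold higher number from compound 1 to compound 2 (0.69 log units; beyond the scatter).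

Compound 4, `CCC(=O)N1c2ccccc2CCC1C(=O)Nc1cc(C(F)(F)F)cc(C(F)(F)F)c1`, differs from compound 3 in one place: propanoyl in place of hydrogen on a nitrogen on an aromatic ring in a ring. Both steps that bear on this change point the same way: an acyl group on that nitrogen lowered the number, by a large amount with one chlorophenyl carbonyl and by a modest amount with the other. Propanoyl is a smaller acyl group than either of those, so a modest fall is expected rather than a large one. Compound 4 is therefore expected to give 2200 nM, with a range from 700 nM to 6500 nM. That estimate for compound 4 means an expected step of a 3.8-fold lower number from compound 3 to compound 4 (0.58 log units; beyond the scatter).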

Compound 4, concentration for 50% growth inhibition: 7820 nM
The estimate for compound 4 lay 3.6-fold (0.55 log units) below the measured number; the whole stated range lies below it.
By their numbers in this assay, from the lowest: compound 1; then compound 2; then compounds 4 and 3 (each within the scatter of the next).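

In this assay propanoyl on the ring nitrogen gives a 1.1-fold lower number from compound 3 to compound 4 (0.03 log units; within the scatter) and so cannot be told apart from the free nitrogen, which shows that an acyl group at this position does not by itself lower the number. What the carbonyl carries makes the difference here: ethyl in place of 2-chlorophenyl gives a 3.8-fold higher number from compound 2 to compound 4 (0.58 log units; beyond the scatter) and ethyl in place of 3-chlorophenyl gives a 19-fold higher number from compound 1 to compound 4 (1.27 log units; beyond the scatter) on that same carbonyl, so among these four compounds only the two chlorophenyl carbonyl groups stand apart from the free nitrogen. Nothing at hand explains why the chlorophenyl groups and propanoyl behave so differently.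

Still open, on these data alone, is whether the chlorine is needed or a plain benzoyl group would serve as well, and whether 4-chlorophenyl on the carbonyl would extend the difference already seen between the two chlorophenyl compounds. Also open, as far as these compounds go, is whether a longer chain such as hexanoyl, or a cyclohexylcarbonyl group, would behave like propanoyl or like the chlorophenyl groups.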